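The source may hold more compounds than are shown below. What is called first, only, known or untested is meant among the compounds shown, and "the series" means these compounds.

In a functional assay on HCT-116 cells (Homo sapiens) for antiproliferative activity, read by MTT assay, with a stated time of 24 h (on this read-out higher numbers stand for weaker inhibition and lower numbers for stronger inhibition), compound 1 (`COc1ccc(/C=C/C(=O)c2ccc(OC)c3c2OC(C)(C)C=C3)c(F)c1`) gives only a limit, > 10000 nM, not a number. Within the data shown here, compound 2 (`COc1ccc(C(=O)/C=C/c2ccc(Cl)c(Cl)c2)c2c1C=CC(C)(C)O2`) gives 9440 nM, the only true number so far. Compound 3 (`COc1ccc(C(=O)/C=C/c2ccccc2Cl)c2c1C=CC(C)(C)O2`) carries 2-chlorophenyl in place of 3,4-dichlorophenyl on a double-bonded chain carbon bound to a double-bonded chain carbon. One measured step changes this same place, an at least 1.0-fold lower number from compound 1 to compound 2 (0.02 log units; that floor lies within the scatter), and its floor lies within the scatter. Also relevant is the limit of > 10000 nM in this assay, at which 1 of the 2 values shown sits. On this thin evidence, no step beyond the scatter is expected in this assay, and the estimated change is a 1.1-fold higher number from compound 2 to compound 3 (0.03 log units; within the scatter). For compound 3 the expected value is 10000 nM, with an estimated range of 4500 nM to 22000 nM.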

Compound 3, half-maximal inhibitory concentration: > 10000 nM
Compound 3 was reported as a limit; the forecaster's own chance of this, stated with the estimate: 50%; the middle value sits exactly at the limit.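

In this assay, the change from 3,4-dichlorophenyl to 2-chlorophenyl on this chain carbon gives an at least 1.0-fold higher number from compound 2 to compound 3 (0.02 log units; that floor lies within the scatter), so a second chlorinated ring also brings no readable gain in inhibition. The value of compound 3 is a limit, not a number, and the step between compound 1 and compound 3 cannot be read. This position can barely be judged here because so many values stop at the same limit: the limit of > 10000 nM in this assay, at which 2 of the 3 values shown sit.

Still open, as far as these compounds go, is whether a ring carrying an amine or a carboxylic acid at this place would give a clearly lower number.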